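A few compounds are considered here, and "the series" means these few. Any claim that something is new, unique, unknown or untested is made for them only; others in the source may bear on it.

Two amides share one core: compound 1 `O=C(Nc1ccccc1)C1(c2ccccc2)CCCC1` and compound 2 `CN(C(=O)C1(c2ccccc2)CCCC1)C1CCCCC1`. In an ADME assay on MDCK cells (Canis lupus familiaris) for cytotoxicity (a lower number here means that less compound is tolerated, a higher number that more compound is tolerated), compound 1 gives a result at the limit of > 100000 nM, a limit rather than a number. In this assay, going by the values given here, compound 2 gives 21000 nM, the only actual number among the values shown. Compound 3 `CN(C(=O)C1(c2ccccc2)CCCC1)c1cccnc1` carries pyridin-3-yl in place of cyclohexyl on an amide-type nitrogen. Among the compounds with values here, no measured pair shows how large such a change is here, so the step from compound 2 to compound 3 is estimated as a 2.4-fold higher number from compound 2 to compound 3 (0.38 log units; beyond the scatter), expected to run upward. Compound 3 is expected to give about 50000 nM, with a range from 15000 nM to 150000 nM.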

Compound 3, half-maximal cytotoxic concentration: > 100000 nM
Compound 3 gave a limit, no number; the forecaster's own chance of this, stated with the estimate: 35%; middle value at least 2.0-fold (0.30 log units) away from the limit.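

Putting pyridin-3-yl in place of cyclohexyl on the amide-type nitrogen gives an at least 4.7-fold higher number from compound 2 to compound 3 (0.67 log units; beyond the scatter) in this assay. Going by these compounds alone, this is the first sign that the group at this position can change how much compound the cells tolerate. The step is only a lower bound, and its full size stays hidden: the limit of > 100000 nM in this assay, at which 2 of the 3 values shown sit.

The change swaps a non-aromatic carbon ring for an aromatic ring holding a nitrogen, so the compounds shown cannot separate those two features. A piperidin-4-yl group or a carboxylic acid at this position could help to tell them apart.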